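This account rests on a few compounds, and the source may have more. Where it says the series, first, only, none or still open, it means among the compounds named here.

Measured so far in an ADME assay on Vero cells (Chlorocebus sabaeus) for cytotoxicity, read by MTT assay, with a stated time of 72 h; on this read-out lower numbers stand for stronger inhibition and higher numbers for weaker inhibition:
compound 1 `COc1ccc2c(c1)[n+]([O-])c(C#N)c(-c1ccc(F)cc1)[n+]2[O-]`, 95.1 ug/mL
compound 2 `COC(=O)c1ccc(-c2c(C#N)[n+]([O-])c3cc(F)ccc3[n+]2[O-])cc1`, 57.5 ug/mL

Compound 2 and compound 1 give numbers in this assay that fall within the scatter of each other; on the values shown nothing separates them. Compound 3 `COC(=O)c1ccc(-c2c(C#N)[n+]([O-])c3cc(OC)ccc3[n+]2[O-])cc1` has not yet been measured. It differs from compound 2 in one place: methoxy in place of fluoro on an aromatic carbon. Among the compounds with values here, a methoxy group already sits on the shared core of compound 1, and compound 1 in this assay lies within the scatter of compound 2, so no recorded step links this change to any movement of the read-out. The expectation for compound 3 is therefore a step of a 1.3-fold higher number from compound 2 to compound 3 (0.12 log units; within the scatter) that stays within the scatter, with no direction beyond it. Compound 3 is estimated at 75 ug/mL in this assay, with a range from 40 ug/mL to 140 ug/mL.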

Compound 3, half-maximal inhibitory concentration: 3.9 ug/mL
Compound 3: the middle estimate sits 19-fold (1.28 log units) above what was measured; the whole stated range lies above it.
By their numbers in this assay, from the lowest: compound 3; then compounds 2 and 1 (each within the scatter of the next).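

In this assay this aromatic carbon turns out to matter: with methoxycarbonyl present, methoxy in place of fluoro gives a 15-fold lower number from compound 2 to compound 3 (1.17 log units; beyond the scatter). Methoxy alone does not produce this, as compound 1 carries it too, and methoxycarbonyl in place of fluoro on the other aromatic ring gives a 24-fold lower number from compound 1 to compound 3 (1.39 log units; beyond the scatter), so among these three compounds the low number appears only where methoxy and methoxycarbonyl occur together. No measurement shown accounts for this large step.

Open, from the compounds shown here alone, is whether ethoxy or an amine on this aromatic carbon would behave like methoxy. Also open, going by these compounds, is whether a carboxylic acid in place of methoxycarbonyl would keep the low number.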